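Capping the ring amine of compound 3 with an amide chain

A few compounds are considered here, and "the series" means these few. Any claim that something is new, unique, unknown or untested is made for them only; others in the source may bear on it.

Of the compounds shown here, three have been measured in a physicochemical assay for lipophilicity, using the shake flask method, measured as octanol-water partition, at pH 7.4; a lower number here means a more polar compound, a higher number a more lipophilic compound. Compound 1 `CC(C)n1nc(-c2ccnc3[nH]c(C4CCN(CC(=O)N(C)C)CC4)cc23)ccc1=O` gives 2, compound 2 `CN(C)C(=O)CN1CCC(c2cc3c(-c4ccc(=O)n(C)c4)ccnc3[nH]2)CC1` gives 1.1, and compound 3 `CC(C)n1cc(-c2ccnc3[nH]c(C4CCNCC4)cc23)ccc1=O` gives -0.2, the lowest of the three. Compound 4 `CC(C)n1cc(-c2ccnc3[nH]c(C4CCN(CC(=O)N5CCCC5)CC4)cc23)ccc1=O` is not yet measured; it differs from compound 3 by ((pyrrolidin-1-yl)carbonyl)methyl in place of hydrogen on an amine nitrogen in a ring. Among the compounds with values here, the only measured step, a number 0.90 log units lower from compound 1 to compound 2 (beyond the scatter), concerns a different part of the shared core and so bears only loosely on this change. Compound 2, which carries a related amide chain on the same amine nitrogen, sits well above compound 3, although it also differs elsewhere. A rise in this assay of about a number 1.80 log units higher from compound 3 to compound 4 (beyond the scatter) is therefore expected, and compound 4 is estimated at 1.6, likely between 1 and 2.2.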

Compound 4, distribution coefficient: 2.1
Compound 4: the middle estimate sits 0.50 log units below what was measured; the measured number falls inside the stated range.
By their numbers in this assay, from the lowest: compound 3; then compound 2; then compounds 1 and 4 (each within the scatter of the next).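

In this assay, within the data shown here, ((pyrrolidin-1-yl)carbonyl)methyl in place of hydrogen on the ring amine nitrogen gives a number 2.30 log units higher from compound 3 to compound 4 (beyond the scatter) and is the first measured step at this position. It shows that this one change on the nitrogen can move the number by a large amount, whereas the earlier step concerned a different part of the shared core. Nothing available accounts for the size of this step.

Going by these compounds, how a plain acetyl group or a longer chain on this nitrogen would compare with compound 4 remains open. Also open, on these data alone, is whether the same step would appear on a different core.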